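A few compounds are considered here, and "the series" means these few. Any claim that something is new, unique, unknown or untested is made for them only; others in the source may bear on it.

Compound 1 `COc1ccc(O)c(C(=O)/C=C/c2csc3ccccc23)c1`: 580 nM
Compound 2 `COc1ccc(C(=O)/C=C/c2csc3ccccc23)c(O)c1`: 5600 nM

These two compounds have the same atoms, arranged differently, and both were tested in a functional assay on A549 cells (Homo sapiens) for antiproliferative activity, read by sulforhodamine B assay, with a stated time of 72 h; a lower number here means a stronger inhibitor, a higher number a weaker inhibitor. Of the two, compound 2 stands highest at 5600 nM, and compound 1 lies lower by more than the usual scatter.

Compound 3 `COc1cc(O)c(C(=O)/C=C/c2csc3ccccc23)cc1OC` is compound 2 with one change, a methoxy in place of hydrogen on an aromatic carbon. For the measured compounds named here, no measured pair shows this exact change on its own, so any forecast is loose. Compound 1 also carries a methoxy para to a hydroxy group and gives 580 nM, so a moderate drop in the number, towards a stronger inhibitor, is expected. The expected change is a 3.1-fold lower number from compound 2 to compound 3 (0.49 log units; beyond the scatter). Compound 3 is estimated at 1800 nM, with an expected range of 400 nM to 7000 nM.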

Compound 3, half-maximal inhibitory concentration: 450 nM
Estimate against measurement, compound 3: 4.0-fold (0.60 log units) above; low and high end bracket the measured number.
By their numbers in this assay, from the lowest: compounds 3 and 1 (each within the scatter of the next); then compound 2.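

On compound 2, a methoxy placed para to a hydroxy group and ortho to a methoxy group gives a 12-fold lower number from compound 2 to compound 3 (1.09 log units; beyond the scatter) in this assay, so this position strongly affects the number, and the change points towards a stronger inhibitor. The step of a 1.3-fold lower number from compound 1 to compound 3 (0.11 log units; within the scatter) shows the same kind of change making no difference that can be told from scatter, so compound 1 and compound 3 stand level in this assay even though compound 2 does not. Nothing measured here explains why the added methoxy matters on compound 2.

The compounds shown leave open whether the gain needs a methoxy specifically, since a longer chain such as ethoxy, an amine or a chlorine at this position could behave differently. They also leave open whether any further group on this ring would lower the number beyond the level of compound 3.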